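The source may report more compounds than this note shows. Statements on the series, on what has been measured and on what is new or still open speak of the compounds shown alone.

Measured in an assay on mitochondria (strain BALB/c) for inhibition of glycerol-3-phosphate acyltransferase 1, mitochondrial (Mus musculus), read by scintillation counting, with a stated time of 10 min; a higher number here means a weaker inhibitor, a lower number a stronger inhibitor:
Compound 1 `CCCCCCCCS(=O)(=O)Nc1ccc(-c2ccc(CCCC)cc2)cc1C(=O)O` gives 9000 nM.
Compound 2 `CCCCCCCCS(=O)(=O)Nc1ccc(/C=C/c2ccccc2)cc1C(=O)O` gives 16300 nM.

Compound 2 holds the higher of the two numbers, yet the step of a 1.8-fold higher number from compound 1 to compound 2 (0.26 log units; within the scatter) lies within the scatter, so neither compound can be called the weaker inhibitor. Compound 3 `CCCCCCCCS(=O)(=O)Nc1ccc(CCc2ccccc2)cc1C(=O)O` differs from compound 2 by phenethyl in place of 2-phenylethenyl on an aromatic carbon. Within the data shown here, no measured step bears directly on this change; the single measured step exchanges whole groups and stayed within the scatter. Compound 3 is therefore expected to remain close to compound 2, with an expected step of a 1.2-fold lower number from compound 2 to compound 3 (0.07 log units; within the scatter), and its estimated value in this assay is 14000 nM, within a range from 5000 nM to 40000 nM.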

Compound 3, half-maximal inhibitory concentration: 37500 nM
Compound 3: middle estimate off by 2.7-fold (0.43 log units), on the low side; the measured number falls inside the stated range.
By their numbers in this assay, from the lowest: compounds 1 and 2 (each within the scatter of the next); then compound 3.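

Phenethyl in place of 2-phenylethenyl, on the aromatic carbon para to a large group, gives a 2.3-fold higher number from compound 2 to compound 3 (0.36 log units; beyond the scatter) in this assay, so the loss of the one double bond outside aromatic rings, with the heavy atom count unchanged, is enough to move the number beyond the scatter. Phenethyl in place of 4-butylphenyl gives a 4.2-fold higher number from compound 1 to compound 3 (0.62 log units; beyond the scatter), so this position does separate these groups. Nothing available here accounts for either step. The compounds shown leave open how an amide or an ether linking group would read at this position, and whether a longer chain such as phenylpropyl would follow phenethyl.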